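A New Five-Membered Ring on the Shared Side Chain

The source may hold more compounds than are shown below. What is called first, only, known or untested is meant among the compounds shown, and "the series" means these compounds.

Among the compounds with values here, in an assay on CHO cells for displacement of a labelled ligand from prostaglandin E2 receptor EP3 subtype (Homo sapiens), read by radioligand binding (a lower number here means a stronger inhibitor, a higher number a weaker inhibitor), compound 2 `CC(C)C(Nc1nccs1)c1ccc(-c2ccc3cccc(F)c3c2)[nH]c1=O` gives 9.4 nM, the lowest of the two numbers measured so far. Compound 1 `CC(C)C(c1ccc(-c2ccc3cccc(F)c3c2)[nH]c1=O)N1CCN/C1=N\C#N` gives 23 nM in this assay, and the step of a 2.4-fold lower number from compound 1 to compound 2 (0.39 log units; beyond the scatter) shows that exchanging the group on that saturated chain carbon can move the number beyond the scatter, though only modestly. Compound 3 `CC(C)C(Cc1noc(=O)[nH]1)c1ccc(-c2ccc3cccc(F)c3c2)[nH]c1=O` has not yet been measured in this assay. It differs from compound 2 by a group of 7 heavy atoms (3 carbon, 2 nitrogen, 2 oxygen; one five-membered aromatic ring with 3 hetero atoms) in place of a group of 6 heavy atoms (3 carbon, 2 nitrogen, 1 sulfur; one five-membered aromatic ring with 2 hetero atoms), on a saturated chain carbon bound to an aromatic carbon and a saturated chain carbon. Within the data shown here, no measured step covers this exact exchange, so the only guide is the single earlier swap at the same place, which was modest in size. A change of similar size is therefore expected, with the direction uncertain, so compound 3 is expected to give about 20 nM in this assay, within a range from 5 nM to 80 nM. This estimate means an expected step of a 2.1-fold higher number from compound 2 to compound 3 (0.33 log units; beyond the scatter).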

Compound 3, inhibition constant: 34 nM
Estimate against measurement, compound 3: 1.7-fold (0.23 log units) below, within the range that was stated.
By their numbers in this assay, from the lowest: compound 2; then compounds 1 and 3 (each within the scatter of the next).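

In this assay, the step of a 3.6-fold higher number from compound 2 to compound 3 (0.56 log units; beyond the scatter) shows that two five-membered aromatic rings on this saturated chain carbon are not interchangeable, even though the leaving and entering groups carry the same counts of hydrogen-bond donors and acceptors. The step of a 1.5-fold higher number from compound 1 to compound 3 (0.17 log units; within the scatter) lies within the scatter, so the non-aromatic ring group of compound 1 and the new aromatic ring of compound 3 cannot be told apart here. Across these compounds, this carbon has so far carried three different five-membered rings with only modest steps among them.

On these data alone, whether a much simpler group, such as a plain amine or a carboxylic acid, would hold up at this carbon remains open. Nothing measured here speaks to why these steps have the size they do.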